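The source may hold more compounds than are shown below. What is called first, only, known or untested is meant among the compounds shown, and "the series" means these compounds.

Measured so far in a functional assay on SAOS-2 cells (Homo sapiens) for antiproliferative activity, read by MTT assay, with a stated time of 72 h; on this read-out lower numbers stand for stronger inhibition and higher numbers for weaker inhibition:
compound 1, `NC1=C(C(=O)c2ccccc2)C(c2ccc(Br)cc2)N(CCCn2ccnc2)C1=O`, gives 107000 nM;
compound 2, `O=C(C1=C(Nc2ccc(F)cc2)C(=O)N(CCCn2ccnc2)C1c1ccc(Br)cc1)c1ccccc1`, gives 32700 nM.

Of these two numbers, compound 2 stands lowest, and its nearest neighbour is compound 1, which lies higher by the step of a 3.3-fold lower number from compound 1 to compound 2 (0.51 log units; beyond the scatter). That step came from 4-fluorophenyl in place of hydrogen on an amine nitrogen, so it shows only that the whole (4-fluorophenyl)amino group is worth something here; it says nothing about what sits on that phenyl ring.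

Compound 3, `O=C(C1=C(Nc2ccc(OC(F)(F)F)cc2)C(=O)N(CCCn2ccnc2)C1c1ccc(Br)cc1)c1ccccc1`, differs from compound 2 by trifluoromethoxy in place of fluoro on an aromatic carbon. The change keeps the (4-fluorophenyl)amino motif and swaps only the group para to a large group. Within the data shown here, no measured pair isolates such a swap, and the one step available, a 3.3-fold lower number from compound 1 to compound 2 (0.51 log units; beyond the scatter), is modest even for a far larger change. The expectation is therefore a step in this assay of at most modest size, more likely within the scatter than beyond it, with a slight lean toward a lower number. Compound 3 is estimated at 25000 nM, in a range from 10000 nM to 70000 nM, which means an expected step of a 1.3-fold lower number from compound 2 to compound 3 (0.12 log units; within the scatter).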

Compound 3, half-maximal inhibitory concentration: 17900 nM
Compound 3: middle estimate off by 1.4-fold (0.15 log units), on the high side; low and high end bracket the measured number.
By their numbers in this assay, from the lowest: compounds 3 and 2 (each within the scatter of the next); then compound 1.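

In this assay, the earlier pair said nothing about the group on the phenyl ring, and here trifluoromethoxy in place of fluoro, on an aromatic carbon para to a large group, gives a 1.8-fold lower number from compound 2 to compound 3 (0.26 log units; within the scatter) and so stays within the scatter, even though 5 heavy atoms and 1 hydrogen-bond acceptor enter where 1 heavy atom and no acceptor leave. The benefit of an aryl group on the amine nitrogen is also not tied to the (4-fluorophenyl)amino group, since 4-(trifluoromethoxy)phenyl in place of hydrogen gives a 6.0-fold lower number from compound 1 to compound 3 (0.78 log units; beyond the scatter) and this step, though still modest, lies beyond the scatter, as the step with 4-fluorophenyl does. No measurement in hand explains these numbers.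

From the compounds shown here alone, whether a carboxylic acid, a dimethylamino group or a plain methyl at this place on the phenyl ring would give a number beyond the scatter remains open. Going by these compounds, it is also open whether a pyridine ring in place of the phenyl ring on the amine nitrogen would keep the step seen from the unsubstituted amine in this assay at all.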